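Cyano for methylsulfonyl: permeability of an aryl nitrile

A few compounds are considered here, and "the series" means these few. Any claim that something is new, unique, unknown or untested is made for them only; others in the source may bear on it.

Compound 1 `CC(=O)N1CCN(c2cc(-c3cc(Cl)c4c(N)ncnn34)ccc2C(F)(F)F)C(=O)C1(C)C`: 150 nm/s in an ADME assay on Caco-2 cells (Homo sapiens) for permeability, in the apical to basolateral direction; on this read-out higher numbers stand for higher permeability and lower numbers for lower permeability
Compound 2 `CC(=O)N1CCN(c2cc(-c3cc(Cl)c4c(N)ncnn34)ccc2S(C)(=O)=O)C(=O)C1(C)C`: "not determined" (no result reported) in this assay

Compound 2 stands without a number on this read-out, since for compound 2 the result is "not determined" (no result reported); only compound 1 gives a measured value, 150 nm/s. Compound 3 `CC(=O)N1CCN(c2cc(-c3cc(Cl)c4c(N)ncnn34)ccc2C#N)C(=O)C1(C)C` differs from compound 2 in one place: cyano in place of methylsulfonyl on an aromatic carbon. Going by the values given here, with no measured step to lean on, a moderate rise beyond the scatter is expected from compound 2 to compound 3, though the direction rests on expectation alone. For compound 3 the estimated permeability is 100 nm/s, within a range from 40 nm/s to 250 nm/s.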

Compound 3, apparent permeability: 200 nm/s
The estimate for compound 3 lay 2.0-fold (0.30 log units) below the measured number; the range from low to high includes it.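

In this assay, cyano in place of trifluoromethyl on this aromatic carbon gives a 1.3-fold higher number from compound 1 to compound 3 (0.12 log units; within the scatter), so the two groups cannot be told apart on this read-out. Compound 2 has no number, so the steps from it cannot be read, and the swap of methylsulfonyl for cyano remains without a size. Nothing shown gives a reason for this result.

Open, as far as these compounds go, is how an amine, a carboxylic acid or a longer chain on this aromatic carbon would read in this assay. Also open, from the compounds shown here alone, is whether the shared core would respond in the same way to a change elsewhere.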